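Adding a Methyl Where Every Neighbour Sits at the Limit

A few compounds are considered here, and "the series" means these few. Any claim that something is new, unique, unknown or untested is made for them only; others in the source may bear on it.

Compound 1 `Cc1ccc2c(c1)C1(C(=O)N2C)C(C#N)=C(N)Oc2cc3oc(-c4ccccc4)cc(=O)c3c(O)c21` — in a functional assay on PC-3 cells (Homo sapiens) for antiproliferative activity, read by MTT assay, with a stated time of 48 h (a higher number here means a weaker inhibitor, a lower number a stronger inhibitor), compound 1 gives > 50000 nM, which is a limit of the assay and not a number.
Compound 2 `Cc1ccc2c(c1)C1(C(=O)N2Cc2ccccc2)C(C#N)=C(N)Oc2cc3oc(-c4ccccc4)cc(=O)c3c(O)c21` — in this assay compound 2 gives > 50000 nM, again a limit and not a number.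
Compound 3 `N#CC1=C(N)Oc2cc3oc(-c4ccccc4)cc(=O)c3c(O)c2C12C(=O)Nc1ccccc12` — in this assay compound 3 gives > 50000 nM, once more a limit rather than a number.

All three measured compounds share one core and differ only at the edges. Compound 3 therefore stands where every other measured compound stands: at the limit of the assay, with no number to rank it by the limit of > 50000 nM in this assay, at which 3 of the 3 values shown sit.

Compound 4 `Cc1ccc2c(c1)C1(C(=O)N2)C(C#N)=C(N)Oc2cc3oc(-c4ccccc4)cc(=O)c3c(O)c21` is reached from compound 3 by one change: methyl in place of hydrogen on an aromatic carbon.

Within the data shown here, only one measured step exists, a step that the two limits leave unreadable from compound 1 to compound 2, and it cannot be read because both of its ends are limits. It concerns a different position in any case, so nothing measured bears directly on the added methyl.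

With all three measured compounds at the limit, compound 4 is expected to sit there too, and the step that the limit leaves unreadable from compound 3 to compound 4 is estimated as none beyond the scatter. For compound 4 the expected value in this assay is 80000 nM, within a range of 25000 nM to 300000 nM.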

Compound 4, half-maximal inhibitory concentration: > 50000 nM
Compound 4: a limit, no number (the forecaster's own chance of this, stated with the estimate: 85%); the middle value is on the limit's open side.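

Compound 4 joins compound 1, compound 2 and compound 3 at the same limit, so none of the steps from those three compounds to compound 4 can be read: the limit of > 50000 nM in this assay, at which 4 of the 4 values shown sit.

The compounds shown leave open whether any change at the edges of the shared core gives a true number in this assay at all, and whether the added methyl alters the activity.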